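The source may report more compounds than this note shows. Statements on the series, on what has been measured and on what is new or still open speak of the compounds shown alone.

Measured in a physicochemical assay for lipophilicity, read by LC-MS, in phosphate buffer, measured as octanol-water partition, at pH 7.4; a higher number here means a more lipophilic compound, a lower number a more polar compound:
compound 1 `COc1cc(N(CC2CC2)c2ccc(F)c3ccccc23)cnc1C(=O)[C@H]1C[C@@H]1C(=O)O` gives 1.9;
compound 2 `COc1cc(N(CC(C)C)c2ccc(F)c3ccccc23)cnc1C(=O)[C@H]1C[C@@H]1C(=O)O` gives 2.2;
compound 3 `COc1cc(N(CC2CC2)c2cccc(C(F)(F)F)c2)cnc1C(=O)[C@H]1C[C@@H]1C(=O)O` gives 1.4.

Compound 1 and compound 2 share a core and differ by isopropyl in place of cyclopropyl on a saturated chain carbon bound to a nitrogen on an aromatic ring. The step is a number 0.30 log units higher from compound 1 to compound 2 (within the scatter). Compound 3 carries a different core; the difference between the two cores is not broken down here, and compound 3 sits at the lowest value of the three.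

Compound 4 `COc1cc(N(CC(C)C)c2cccc(C(F)(F)F)c2)cnc1C(=O)[C@H]1C[C@@H]1C(=O)O` is not yet measured. It differs from compound 3 by isopropyl in place of cyclopropyl on a saturated chain carbon bound to a nitrogen on an aromatic ring, the same change as from compound 1 to compound 2, at the same place. The expected step for compound 4 is a number 0.30 log units higher from compound 3 to compound 4 (within the scatter), resting on the earlier step of a number 0.30 log units higher from compound 1 to compound 2 (within the scatter) and on compound 3 at 1.4. Compound 4 is thus estimated at 1.7, with a range from 1.3 to 2.1.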

Compound 4, distribution coefficient: 1.6
Compound 4: middle estimate off by 0.10 log units, on the high side, within the range that was stated.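

In this assay, isopropyl in place of cyclopropyl gives a number 0.20 log units higher from compound 3 to compound 4 (within the scatter), and on the core of compound 1 the same change gives a number 0.30 log units higher from compound 1 to compound 2 (within the scatter). Both steps lie within the scatter, so the two cores agree only in that neither shows a step distinguishable from repeat measurement, which does not establish a real effect of the change on either core or predict its size on any further core. No measured evidence bears on why the steps read as they do. Open, going by these compounds, is whether a longer chain or an amine at the same place would give a step beyond the scatter. Also open, on these data alone, is whether a carboxylic acid replaced by an amide would leave this reading unchanged.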